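From 2H-tetrazol-5-yl to 2-methyl-2H-tetrazol-5-yl

The compounds below may be only part of what the source reports. "The series", "measured", "known", "first", "only" and "open" are said of these compounds alone.

Measured in a functional assay (blood) for inhibition, with Homo sapiens as the target; a higher number here means a weaker inhibitor, a lower number a stronger inhibitor:
compound 1 `COCc1cc(-c2ccccc2)c2ccc(OCc3cccc(C4(O)CCOCC4)c3)cc2c1`: 200 nM
compound 2 `OC1(c2cccc(COc3ccc4c(-c5ccccc5)cc(-c5nn[nH]n5)cc4c3)c2)CCOCC1`: > 3000 nM (a limit)

Compound 2 has only a limit, (the limit of > 3000 nM in this assay, at which 1 of the 2 values shown sits).

Compound 3 `Cn1nnc(-c2cc(-c3ccccc3)c3ccc(OCc4cccc(C5(O)CCOCC5)c4)cc3c2)n1` carries methyl in place of hydrogen on an aromatic nitrogen. For the measured compounds named here, the only measured step that touches this group is large: an at least 15-fold higher number from compound 1 to compound 2 (1.17 log units; beyond the scatter). It is a different change, so it offers only a loose guide. A large move to a lower number in this assay is expected, back towards compound 1 at 200 nM. The expected change is an at least 7.5-fold lower number from compound 2 to compound 3 (0.87 log units; beyond the scatter). For compound 3 the estimated value is 400 nM, with an expected range of 100 nM to 2000 nM.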

Compound 3, half-maximal inhibitory concentration: 310 nM
Beside the measured number, compound 3's estimate is 1.3-fold (0.11 log units) above it; the range from low to high includes it.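

In this assay compound 2 is known only as a limit: the limit of > 3000 nM in this assay, at which 1 of the 3 values shown sits. Putting methyl on the aromatic nitrogen still gives a clear change, an at least 9.6-fold lower number from compound 2 to compound 3 (0.98 log units; beyond the scatter), so the hydrogen on that nitrogen matters here. With a 1.6-fold higher number from compound 1 to compound 3 (0.19 log units; within the scatter), 2-methyl-2H-tetrazol-5-yl and methoxymethyl cannot be told apart on this aromatic carbon, so an intact ring with 4 nitrogen is tolerated there once it is methylated. The compounds leave open whether ethyl or a longer chain on that nitrogen would behave like methyl. They also leave open how a carboxylic acid would fare in place of the ring.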